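The compounds below may be only part of what the source reports. "The series", "measured", "known", "first", "only" and "open" are said of these compounds alone.

Two compounds share one core and differ only in the group carried on an amide-type nitrogen. Compound 1, `Cc1ccc(S(=O)(=O)NNC(=O)COc2ccc3cc(C(O)(C(F)(F)F)C(F)(F)F)c(O)cc3c2)cc1`, bears a ((4-methylphenyl)sulfonyl)amino group there, while compound 2, `O=C(COc1ccc2cc(C(O)(C(F)(F)F)C(F)(F)F)c(O)cc2c1)Nc1cccc2ccccc12`, bears a naphthalen-1-yl group. In an assay on isolated protein for inhibition of tyrosine-protein phosphatase non-receptor type 13 (Homo sapiens), read by spectrophotometry (a lower number here means a stronger inhibitor, a higher number a weaker inhibitor), compound 1 gives 14900 nM. In this assay compound 2 gives > 20000 nM, which is a limit of the assay and not a number, sitting at the limit of > 20000 nM in this assay, at which 1 of the 2 values shown sits. For the measured compounds named here, the only measured step, an at least 1.3-fold higher number from compound 1 to compound 2 (0.12 log units; that floor lies within the scatter), thus has a floor but no known size, and the floor itself lies within the scatter. Compound 3, `CC(C)c1ccc(NC(=O)COc2ccc3cc(C(O)(C(F)(F)F)C(F)(F)F)c(O)cc3c2)cc1`, has not yet been measured. It differs from compound 2 in one place: 4-isopropylphenyl in place of naphthalen-1-yl on an amide-type nitrogen. Going by the values given here, no measured step tests this exchange, and the one measured step concerns a different group, so the expectation rests on compound 2 standing at a limit and on the change being small. The expected step is a step that the limit leaves unreadable from compound 2 to compound 3, in effect none beyond the scatter. Compound 3 is therefore expected to give about 25000 nM in this assay, within a range from 8000 nM to 80000 nM.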

Compound 3, half-maximal inhibitory concentration: 6500 nM
The estimate for compound 3 lay 3.8-fold (0.59 log units) above the measured number; the measured number lies below the stated range.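

In this assay, the exchange at the amide-type nitrogen, which puts the single aromatic ring of 4-isopropylphenyl where the two rings of naphthalen-1-yl stood, gives an at least 3.0-fold lower number from compound 2 to compound 3 (0.48 log units; beyond the scatter). The value of compound 2 is a limit of the assay and not a number, so this step has a floor but no known size: the limit of > 20000 nM in this assay, at which 1 of the 3 values shown sits. For the compounds shown here, replacing ((4-methylphenyl)sulfonyl)amino with 4-isopropylphenyl gives a 2.3-fold lower number from compound 1 to compound 3 (0.36 log units; beyond the scatter), the first step of known size at this position, and it makes compound 3 the strongest inhibitor of the three, though that step is only modest.

A plain phenyl group on the same nitrogen would help show whether the lower number goes with having one aromatic ring in place of two or with the isopropyl group itself. On these data alone, it also remains open whether a carboxylic acid or an amine in place of that isopropyl group would lower the number further or raise it again.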